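A few compounds are considered here, and "the series" means these few. Any claim that something is new, unique, unknown or untested is made for them only; others in the source may bear on it.

The study concerns a shared core carried by compound 1 `CN1CCN(CCCN(C[C@H]2Cc3ccccc3CN2)[C@H]2CCCc3cccnc32)CC1`, compound 2 `c1ccc2c(c1)CN[C@H](CN(CCCN1CCNCC1)[C@H]1CCCc3cccnc31)C2`, compound 3 `c1ccc2c(c1)CN[C@@H](CN(CCN1CCNCC1)[C@H]1CCCc3cccnc31)C2` and the unmeasured compound 4 `c1ccc2c(c1)CN[C@@H](CN(CCCN1CCNCC1)[C@H]1CCCc3cccnc31)C2`. In an ADME assay on microsomes from liver (Mus musculus) for metabolic stability, read by LC-MS, with a stated time of 10 min, tested at 0.5 uM (a higher number here means that more of the compound is left, a lower number that less of the compound is left), compound 3 gives 79%, the second highest of the three numbers; compound 2 gives 88%, within the scatter of compound 3, while compound 1 gives 53%, clearly lower. Among the measured compounds shown here, the one measured step, a number 26 percentage points higher from compound 1 to compound 3 (beyond the scatter), combined a change of chain length with removal of a methyl group, so it does not isolate the chain alone.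

Compound 4 differs from compound 3 by (piperazin-1-yl)methyl in place of piperazin-1-yl on a saturated chain carbon, two bonds along the chain from an amine nitrogen. Compound 4 carries the same 3-(piperazin-1-yl)propyl chain as compound 2, and compound 2 gives 88%, a number within the scatter of compound 3, so the lengthening by one chain carbon is not expected to move the number beyond the scatter. The expected step is a number 3 percentage points higher from compound 3 to compound 4 (within the scatter). Compound 4 is therefore estimated at 82% in this assay, with a range from 66% to 95%.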

Compound 4, percent of the compound remaining: 92%
Compound 4: middle estimate off by 10 percentage points, on the low side; the range from low to high includes it.
By their numbers in this assay, from the lowest: compound 1; then compounds 3, 2 and 4 (each within the scatter of the next, the first and the last beyond it).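

Compound 4 separates the two changes that were combined in the earlier step. In this assay, the lengthening of the chain alone, (piperazin-1-yl)methyl in place of piperazin-1-yl on a saturated chain carbon, gives a number 13 percentage points higher from compound 3 to compound 4 (beyond the scatter), while hydrogen in place of methyl on an amine nitrogen in a ring gives, on its own, a number 39 percentage points higher from compound 1 to compound 4 (beyond the scatter). The stereocentre at the saturated ring carbon adds no clear difference, with a number 4 percentage points higher from compound 2 to compound 4 (within the scatter), and this pair reads configuration alone: the fact that compounds 2 and 4 differ only in the configuration as drawn

The compounds shown leave open whether a chain longer than 3-(piperazin-1-yl)propyl would keep this number. They also leave open how an ethyl group on that ring nitrogen, or a morpholine in place of the piperazine, would read in this assay.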